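The source may hold more compounds than are shown below. What is called first, only, known or untested is meant among the compounds shown, and "the series" means these compounds.

Compound 1 `COc1cccc(N2CCN(C(=O)C(C)N3C(=O)CCC3=O)CC2)c1` gives 0% in a functional assay on the whole organism (strain Swiss) with Mus musculus as the target, in the maximal electroshock model, with a stated time of 2 h, at a dose of 300 mg/kg by the intraperitoneal route; a lower number here means a weaker effect, a higher number a stronger effect of the compound at the dose given; compound 2 `CC(C(=O)N1CCN(c2ccccc2)CC1)N1C(=O)CCC1=O` gives 0%; compound 3 `CC(C(=O)N1CCN(c2ccc(F)cc2)CC1)N1C(=O)CCC1=O` gives 50%.

Compound 3 stands highest of the three numbers: the step of a number 50 percentage points higher from compound 1 to compound 3 (beyond the scatter) and the step of a number 50 percentage points higher from compound 2 to compound 3 (beyond the scatter) both separate it from the others beyond the scatter. Compound 4 `CC(C(=O)N1CCN(c2cccc(F)c2)CC1)N1C(=O)CCC1=O` differs from compound 3 by 3-fluorophenyl in place of 4-fluorophenyl on an amine nitrogen in a ring. Among the measured compounds shown here, no measured step moves a fluoro between aromatic positions. The step of a number 50 percentage points higher from compound 2 to compound 3 (beyond the scatter) shows that the fluoro itself carried the whole gain, while no change at the digits printed from compound 1 to compound 2 (within the scatter) shows that a methoxy elsewhere on that ring added nothing. Because the gain rests on a number 50 percentage points higher from compound 2 to compound 3 (beyond the scatter) alone, the account expects part of it to be kept. The estimated step is a number 20 percentage points lower from compound 3 to compound 4 (beyond the scatter). Compound 4 is therefore estimated at 30%, within 0% to 60%.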

Compound 4, a percentage reported as activity, at one dose (the size of the read-out at that dose, not a potency): 100%
Compound 4: the middle estimate sits 70 percentage points below what was measured, outside the stated range (above it).
By their numbers in this assay, from the lowest: compounds 1 and 2 (each within the scatter of the next); then compound 3; then compound 4.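

With the same atoms joined differently, 3-fluorophenyl in place of 4-fluorophenyl gives a number 50 percentage points higher from compound 3 to compound 4 (beyond the scatter) in this assay, so the place of the fluoro on this ring matters, not only its presence. That place alone is not enough: the fluoro gives a number 100 percentage points higher from compound 2 to compound 4 (beyond the scatter), and in place of methoxy on the same carbon it gives a number 100 percentage points higher from compound 1 to compound 4 (beyond the scatter). Nothing available here explains this difference.

The compounds shown leave open whether chloro or trifluoromethyl at that place would keep the effect. They also leave open whether a second fluoro on the ring would keep it.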